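A few compounds are considered here, and "the series" means these few. Any claim that something is new, unique, unknown or untested is made for them only; others in the source may bear on it.

Working notes on the series, read in a functional assay on ECa-109 cells (Homo sapiens) for cytotoxicity, read by MTT assay, with a stated time of 72 h; a lower number here means a stronger inhibitor, a higher number a weaker inhibitor. Going by the values given here, compound 1 `O=C1C(=Cc2ccc(Br)cc2)C(=O)N(c2ccc(Cl)cc2)N1c1ccc(Cl)cc1` gives 12300 nM, the lowest of the two numbers so far. Compound 2 `CC(=C1C(=O)N(c2ccc(Cl)cc2)N(c2ccc(Cl)cc2)C1=O)c1ccc(O)cc1` gives 55600 nM, a higher number, and the gap lies beyond the scatter. Among the compounds with values here, no step between measured compounds that differ in one place is available, so the next expectation rests on these two values alone. Compound 3 `COc1cccc(C=C2C(=O)N(c3ccc(Cl)cc3)N(c3ccc(Cl)cc3)C2=O)c1OC` carries 2,3-dimethoxyphenyl in place of 4-bromophenyl on a double-bonded chain carbon bound to a double-bonded ring carbon. Compound 1 at 12300 nM sits at the low end of the numbers seen, so a modest move toward a weaker inhibitor is the working expectation. In this assay the estimated change is a 1.6-fold higher number from compound 1 to compound 3 (0.21 log units; within the scatter), and it may not clear the scatter. For compound 3 the expected value is 20000 nM, with an estimated range of 7000 nM to 60000 nM.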

Compound 3, half-maximal inhibitory concentration: 6800 nM
Compound 3: the middle estimate sits 2.9-fold (0.47 log units) above what was measured, and the stated range ends above it.
By their numbers in this assay, from the lowest: compounds 3 and 1 (each within the scatter of the next); then compound 2.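

In this assay, going by these compounds alone, 2,3-dimethoxyphenyl in place of 4-bromophenyl on a double-bonded chain carbon bound to a double-bonded ring carbon gives the first one-place comparison (a 1.8-fold lower number from compound 1 to compound 3 (0.26 log units; within the scatter)). At this place the two aromatic groups are not separated, although they differ in heavy atoms and 2,3-dimethoxyphenyl brings hydrogen-bond acceptors that 4-bromophenyl lacks, so the substitution is accommodated here without a change that clears the scatter. No measured evidence on the reason for this reading is at hand.

On these data alone, it remains open whether a single methoxy group would read the same, and how an aromatic ring bearing an amine or a carboxylic acid would read at this place. No step shown touches the rest of the core of compound 1, so the effect of changes there also remains open.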